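The source may report more compounds than this note shows. Statements on the series, on what has been measured and on what is new or still open speak of the compounds shown alone.

Measured in a functional assay on EOL1 cells (Homo sapiens) for inhibition, read by fluorescence, with a stated time of 72 h; a lower number here means a stronger inhibitor of growth, a higher number a weaker inhibitor of growth:
- compound 1 `COc1ccc(Cn2cnc3c(Nc4cccc(Cl)c4)nc(N[C@H]4CC[C@H](N)CC4)nc32)cc1`: 530 nM
- compound 2 `CCCCn1cnc2c(NCc3cccc(Cl)c3)nc(N[C@H]3CC[C@H](N)CC3)nc21`: 350 nM

In this assay, compound 1 gives 530 nM, the higher number of the pair on paper, and compound 2 gives 350 nM. These two values lie within the usual scatter of each other, so the pair cannot be ranked and compound 1 has no firm position in the series yet.

The next compound to be measured is compound 3 `N[C@H]1CC[C@H](Nc2nc(Nc3cccc(Cl)c3)c3ncn(Cc4ccccc4)c3n2)CC1`. It keeps the shared core of compound 1 and replaces 4-methoxybenzyl with benzyl: hydrogen in place of methoxy on an aromatic carbon, para to a large group (hydrogen in place of methoxy on an aromatic carbon).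

Among the measured compounds shown here, no measured pair isolates this change, so the data give neither a size nor a direction for it. The working expectation is therefore no shift beyond the scatter in this assay, with the anchor being compound 1 at 530 nM. The estimated move a 1.2-fold lower number from compound 1 to compound 3 (0.07 log units; within the scatter) is expected to stay inside that scatter. For compound 3 the expected value is 450 nM, within an estimated range of 200 nM to 1000 nM.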

Compound 3, concentration for 50% growth inhibition: 380 nM
Estimate against measurement, compound 3: 1.2-fold (0.07 log units) above; the measured number falls inside the stated range.
By their numbers in this assay, from the lowest: compounds 2, 3 and 1 (each within the scatter of the next).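

In this assay, among the compounds shown here, the only pair that isolates this change, hydrogen in place of methoxy on an aromatic carbon, para to a large group, gives a 1.4-fold lower number from compound 1 to compound 3 (0.14 log units; within the scatter). For the compounds shown here, this is the first direct reading at this position: 4-methoxybenzyl and benzyl cannot be told apart in this read-out, so the methoxy group is not required for the growth inhibition seen with the shared core of compound 1. No supporting evidence bears on this result.

Going by these compounds alone, the single step covers only methoxy and hydrogen, so it remains open whether the same aromatic carbon would also tolerate a carboxylic acid, an amine or trifluoromethyl, and what a group at another place on that ring would do. Compound 2 differs from compound 3 in more than one place, so it cannot show the effect of a butyl chain in place of benzyl on its own, and the contribution of that substituent as a whole remains unresolved.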